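Removing the nitro group from compound 3

The source may hold more compounds than are shown below. What is called first, only, known or untested is meant among the compounds shown, and "the series" means these compounds.

In a functional assay on FM3A cells (Mus musculus) for antiproliferative activity (on this read-out higher numbers stand for weaker inhibition and lower numbers for stronger inhibition), compound 3 `COc1cc(C(=O)c2sc(-c3cccc([N+](=O)[O-])c3)cc2N)cc(OC)c1OC` gives 17 nM, the lower of the two actual numbers. Compound 2 `COc1ccc(-c2cc(N)c(C(=O)c3cc(OC)c(OC)c(OC)c3)s2)cc1OC` gives 72 nM. Compound 1 `COc1cc(C(=O)c2sc(-c3ccc(-c4ccccc4)cc3)cc2N)cc(OC)c1OC` gives only a limit, > 10000 nM, rather than a number. Compound 4 `COc1cc(C(=O)c2sc(-c3ccccc3)cc2N)cc(OC)c1OC` has hydrogen in place of nitro on an aromatic carbon, meta to a large group: hydrogen in place of nitro on an aromatic carbon. Among the compounds with values here, the only measured step that bears on this is a 4.2-fold lower number from compound 2 to compound 3 (0.63 log units; beyond the scatter), which brought in 3-nitrophenyl in place of 3,4-dimethoxyphenyl and was modest but beyond the scatter. Losing the nitro is expected to give a similarly modest move toward weaker inhibition, an estimated 4.1-fold higher number from compound 3 to compound 4 (0.61 log units; beyond the scatter). For compound 4, the estimated value is 70 nM, with an expected range of 20 nM to 300 nM.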

Compound 4, half-maximal inhibitory concentration: 13 nM
The estimate for compound 4 lay 5.4-fold (0.73 log units) above the measured number, and the stated range ends above it.
By their numbers in this assay, from the lowest: compounds 4 and 3 (each within the scatter of the next); then compound 2. At a limit, above all of these: compound 1.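

Nitro turns out not to be needed at this position: in this assay, swapping it for hydrogen gives a 1.3-fold lower number from compound 3 to compound 4 (0.12 log units; within the scatter), so the two cannot be told apart. The bare phenyl also improves on 3,4-dimethoxyphenyl, with a 5.5-fold lower number from compound 2 to compound 4 (0.74 log units; beyond the scatter). Measured against a limit rather than a number, hydrogen in place of phenyl is a large step, an at least 760-fold lower number from compound 1 to compound 4 (2.88 log units; beyond the scatter).

From the compounds shown here alone, whether an amine or a carboxylic acid at the place of the nitro would keep the number this low remains open. So does whether any group there can improve on hydrogen.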